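The compounds below may be only part of what the source reports. "The series", "measured", "known", "first", "only" and "open" are said of these compounds alone.

Measured compounds: compound 1 `CCCCCCCCn1cc(COC2(C(F)(F)F)Oc3ccccc3C=C2C(=O)OCC)nn1`, compound 2 `CCOC(=O)C1=Cc2ccccc2OC1(OCc1cc(-c2ccc(Cl)cc2)no1)C(F)(F)F`, compound 3 `O=C(O)C1=Cc2ccccc2OC1(OCc1cc(-c2ccc(F)cc2)no1)C(F)(F)F`.

In a functional assay on MCF7 cells (Homo sapiens) for inhibition, read by MTT assay, with a stated time of 24 h (a lower number here means a stronger inhibitor, a higher number a weaker inhibitor), compound 1 gives only a limit, > 150000 nM, not a number, so compound 1 stands at the weak end of what has been seen (the limit of > 150000 nM in this assay, at which 1 of the 3 values shown sits). Compound 2 gives 18200 nM in this assay. Compound 3 gives 64200 nM in this assay. Compound 4 `CCOC(=O)C1=Cc2ccccc2OC1(OCc1cn(-c2ccc([N+](=O)[O-])cc2)nn1)C(F)(F)F` is not yet measured; it differs from compound 1 by 4-nitrophenyl in place of octyl on an aromatic nitrogen. Among the compounds with values here, no step between two measured compounds is available to anchor this change, so the size of the move rests on where compounds 2 and 3 sit. Compound 4 is expected to move well beyond the scatter, an at least 3.7-fold lower number from compound 1 to compound 4 (0.57 log units; beyond the scatter). The estimate for compound 4 is 40000 nM, between 10000 nM and 150000 nM.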

Compound 4, half-maximal inhibitory concentration: > 150000 nM
Compound 4 ended at the assay's limit (the forecaster's own chance of this, stated with the estimate: 30%); middle value at least 3.7-fold (0.57 log units) from the limit.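

Compound 1 and compound 4 both end at a limit, not a number, so the step between them cannot be read: the limit of > 150000 nM in this assay, at which 2 of the 4 values shown sit.

The compounds shown leave open whether 4-nitrophenyl and octyl on that aromatic nitrogen differ at all in this assay.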